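This account rests on a few compounds, and the source may have more. Where it says the series, first, only, none or still open, it means among the compounds named here.

In a functional assay on MIA PaCa-2 cells (Homo sapiens) for inhibition, read by MTT assay, with a stated time of 7 days (a higher number here means a weaker inhibitor, a lower number a stronger inhibitor), the measured compounds are:

Compound 1 `CCN(CC)S(=O)(=O)c1ccc(S(=O)(=O)N2CCC[C@@H](C(=O)N3CCC(OC)CC3)C2)cc1` gives 140 nM
Compound 2 `CCN(CC)C(=O)c1ccc(S(=O)(=O)N2CCC[C@@H](C(=O)N3CCC(F)(F)CC3)C2)cc1` gives 70 nM

These two values lie within the usual scatter of each other, so they cannot be told apart. Compound 3 `CCN(CC)S(=O)(=O)c1ccc(S(=O)(=O)N2CCC[C@@H](C(=O)N3CCC(COC)CC3)C2)cc1` has not yet been measured. It carries methoxymethyl in place of methoxy on a saturated ring carbon and otherwise matches compound 1. Going by the values given here, no measured pair shows this change, so no step beyond the scatter is expected in this assay in either direction. The expected step of a 1.1-fold higher number from compound 1 to compound 3 (0.03 log units; within the scatter) stays within that scatter. For compound 3 the estimated value is 150 nM with an expected range of 55 nM to 400 nM in this measurement.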

Compound 3, half-maximal inhibitory concentration: 250 nM
For compound 3 the middle estimate is 1.7-fold (0.22 log units) below the measured one; the range from low to high includes it.
By their numbers in this assay, from the lowest: compounds 2, 1 and 3 (each within the scatter of the next, the first and the last beyond it).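

In this assay, methoxymethyl in place of methoxy on this saturated ring carbon gives a 1.8-fold higher number from compound 1 to compound 3 (0.25 log units; within the scatter) and so the two compounds cannot be told apart. Going by these compounds alone, this is the first pair here that differs in one place, and it shows that adding this one carbon to the group makes no clear difference at this position. No measurement on hand bears on why this is so. Going by these compounds, it remains open whether an amine, a carboxylic acid or a longer ether chain on the same ring carbon would move the number beyond the scatter.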